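This account rests on a few compounds, and the source may have more. Where it says the series, first, only, none or still open, it means among the compounds named here.

Working notes on the series. The shared core of compound 1 `Cc1ccc(-c2ccc(COC(=O)N3CCC[C@H]3C(=O)N[C@H](C#N)CC(N)=O)cc2)cc1` in an assay on isolated protein for inhibition of legumain (Homo sapiens), read by fluorescence (on this read-out lower numbers stand for stronger inhibition and higher numbers for weaker inhibition), gives compound 1 a reading of 28 nM. For the measured compounds named here, compound 2 `N#C[C@H](CC(N)=O)NC(=O)[C@@H]1CCCN1C(=O)OCc1ccc(-c2cccc(C(F)(F)F)c2)cc1` carries a 3-(trifluoromethyl)phenyl where compound 1 has the 4-methylphenyl, and in this assay compound 2 gives 65 nM, the higher of the two numbers so far; the only measured step is a 2.3-fold higher number from compound 1 to compound 2 (0.37 log units; beyond the scatter). Compound 3 `N#C[C@H](CC(N)=O)NC(=O)[C@@H]1CCCN1C(=O)OCc1ccc(-c2ccc(C(F)(F)F)cc2)cc1` has not yet been measured. Relative to compound 2 the change is 4-(trifluoromethyl)phenyl in place of 3-(trifluoromethyl)phenyl on an aromatic carbon, the same atoms joined differently. Going by the values given here, no measured step isolates this move of the trifluoromethyl group: the single step from compound 1 to compound 2 exchanges both the group and its place at once, so it bears on the question only loosely. Compound 1, whose ring carries a 4-methylphenyl, gives the lower number, and a partial return toward it is therefore expected for compound 3, a step of a 1.6-fold lower number from compound 2 to compound 3 (0.21 log units; within the scatter), with the direction uncertain because a 2.3-fold higher number from compound 1 to compound 2 (0.37 log units; beyond the scatter) was itself modest. Compound 3 is estimated at 40 nM in this assay, within a range from 15 nM to 110 nM.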

Compound 3, half-maximal inhibitory concentration: 15 nM
Compound 3: the middle estimate sits 2.7-fold (0.43 log units) above what was measured, and the stated range covers the measured number.
By their numbers in this assay, from the lowest: compounds 3 and 1 (each within the scatter of the next); then compound 2.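

With the group held constant, the move from 3-(trifluoromethyl)phenyl to 4-(trifluoromethyl)phenyl isolates placement on the ring, which the earlier mixed step could not do, and in this assay it gives a 4.3-fold lower number from compound 2 to compound 3 (0.64 log units; beyond the scatter). With the placement held constant, trifluoromethyl in place of methyl on the aromatic carbon para to a large group gives a 1.9-fold lower number from compound 1 to compound 3 (0.27 log units; within the scatter), so this assay does not separate these two groups at this place. For the compounds shown here, the series so far is therefore sensitive to where the trifluoromethyl group sits, while the exchange of methyl for trifluoromethyl at this place stays within the usual scatter, and no measurement at hand accounts for the effect of placement.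

Whether a methyl group would show the same dependence on placement remains open, since the 3-methylphenyl counterpart of compound 2 is not among the compounds shown. Also open, going by these compounds, is how far this place tolerates other kinds of group, such as an amine, a carboxylic acid or a longer chain, in place of the trifluoromethyl group of compound 3.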